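The source may hold more compounds than are shown below. What is called first, only, known or untested is meant among the compounds shown, and "the series" means these compounds.

Compound 1 `c1ccc(-c2cc(-c3ccsc3)cc(-c3ccccn3)n2)nc1`: 0.1 ug/mL
Compound 2 `c1ccc(-c2cc(-c3ccsc3)cc(-c3cccnc3)n2)nc1`: > 100 ug/mL

Among the measured compounds shown here, in a functional assay on SK-OV-3 cells (Homo sapiens) for antiproliferative activity (on this read-out lower numbers stand for stronger inhibition of growth and higher numbers for weaker inhibition of growth), compound 1 gives 0.1 ug/mL, the only exact number so far. Compound 2 gives only a limit of the assay, > 100 ug/mL.

Compound 3 `c1ccc(-c2cc(-c3ccco3)cc(-c3ccccn3)n2)nc1` keeps the core of compound 1 and has furan-2-yl in place of thiophen-3-yl on an aromatic carbon.

For the measured compounds named here, the one measured step, an at least 1000-fold higher number from compound 1 to compound 2 (3.00 log units; beyond the scatter), is large, but it concerns a pyridine group, not the group changed here. It therefore does not predict this swap directly, although it does show that a single change can shift this read-out sharply. Compound 3 retains both pyridin-2-yl groups, and one five-membered aromatic ring replaces another. The expected change is a 1.5-fold higher number from compound 1 to compound 3 (0.18 log units; within the scatter), which means no shift beyond the scatter in this assay. For compound 3 the estimate is 0.15 ug/mL, with an expected range of 0.02 ug/mL to 2 ug/mL.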

Compound 3, concentration for 50% growth inhibition: 0.13 ug/mL
The estimate for compound 3 lay 1.2-fold (0.06 log units) above the measured number; the range from low to high includes it.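

In this assay, replacing thiophen-3-yl with furan-2-yl on the carbon opposite the ring nitrogen gives a 1.3-fold higher number from compound 1 to compound 3 (0.11 log units; within the scatter) and so no shift that can be told from the scatter. This swap exchanges sulfur for oxygen and also changes the point of attachment on the five-membered ring, yet neither change together with the other moves this read-out, which shows that growth inhibition here can survive a change at this position. Nothing shown offers a reason for this result.

On these data alone, these two compounds cover only five-membered aromatic rings with one hetero atom, so it remains open whether a larger or quite different group at this place, such as a phenyl ring, an amine or a carboxylic acid, would keep the activity. As far as these compounds go, it also remains open whether thiophen-2-yl or furan-3-yl would behave the same way.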